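From an open chain to a ring: compound 4

The source may report more compounds than this note shows. Statements on the series, on what has been measured and on what is new or still open speak of the compounds shown alone.

Measured in a physicochemical assay for solubility, read by LC-MS, in phosphate buffer, with a stated time of 24 h, at pH 7.4; on this read-out higher numbers stand for higher solubility and lower numbers for lower solubility:
compound 1 `CN(c1ncco1)c1cnc(NCc2c(F)ccc3c2CCO3)n2cnnc12` gives 67000 nM
compound 2 `C[C@@H]1CC(=O)N(c2cnc(NCc3c(F)ccc4c3CCO4)n3cnnc23)C1` gives 130000 nM
compound 3 `COCCC(=O)Nc1cnc(NCc2c(F)ccc3c2CCO3)n2cnnc12` gives 980000 nM

Compound 3 has the highest number of the three, clear of both others (a 15-fold higher number from compound 1 to compound 3 (1.17 log units; beyond the scatter)) and (a 7.5-fold higher number from compound 2 to compound 3 (0.88 log units; beyond the scatter)). Compound 4 `CC1(C)CC(=O)N(c2cnc(NCc3c(F)ccc4c3CCO4)n3cnnc23)C1` gives up the ((2-methoxyethyl)carbonyl)amino of compound 3 for 4,4-dimethyl-2-oxopyrrolidin-1-yl on the same aromatic carbon (4,4-dimethyl-2-oxopyrrolidin-1-yl in place of ((2-methoxyethyl)carbonyl)amino on an aromatic carbon). The closest measured comparison is compound 2, which carries 4-methyl-2-oxopyrrolidin-1-yl at that place. Its modest step to compound 3 is therefore the one that bears most, and the change to compound 4 should run roughly that step in reverse. The large step from compound 1 tells less, since that group is not a ring of this kind. Going by the values given here, no measured compound carries 4,4-dimethyl-2-oxopyrrolidin-1-yl, which widens the range. The expected change is a lower number of modest size in this assay (a 9.8-fold lower number from compound 3 to compound 4 (0.99 log units; beyond the scatter)). The estimated value for compound 4 is 100000 nM (expected range 35000 nM to 280000 nM).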

Compound 4, solubility: 57000 nM
Beside the measured number, compound 4's estimate is 1.8-fold (0.24 log units) above it, and the stated range covers the measured number.
By their numbers in this assay, from the lowest: compounds 4, 1 and 2 (each within the scatter of the next, the first and the last beyond it); then compound 3.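

In this assay, the step away from the open ((2-methoxyethyl)carbonyl)amino chain to this ring is a big one, with a 17-fold lower number from compound 3 to compound 4 (1.24 log units; beyond the scatter) on this aromatic carbon. The ring itself is also sensitive to a small edit: a second methyl on it, 4,4-dimethyl-2-oxopyrrolidin-1-yl in place of 4-methyl-2-oxopyrrolidin-1-yl, gives a 2.3-fold lower number from compound 2 to compound 4 (0.36 log units; beyond the scatter) and so moves the number beyond the scatter. Against the quite different methyl(1,3-oxazol-2-yl)amino group, the result is a 1.2-fold lower number from compound 1 to compound 4 (0.07 log units; within the scatter) and the two cannot be told apart in this assay.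

Going by these compounds, it remains open how the plain 2-oxopyrrolidin-1-yl ring with no methyl, a longer chain or an amine on this carbon would compare. No measurement shown here explains any of these steps.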